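One aryl swap from compound 2 to compound 4

This account rests on a few compounds, and the source may have more. Where it says the series, first, only, none or still open, it means among the compounds named here.

Measured in an ADME assay on L6 cells (Rattus norvegicus) for cytotoxicity, read by resazurin assay, with a stated time of 72 h; a higher number here means a weaker inhibitor, a lower number a stronger inhibitor:
- compound 1 `OC(c1ccc(Cl)cc1)(c1ccc(C(F)(F)F)cc1)c1cncnc1` gives 66800 nM
- compound 2 `OC(c1ccc(Cl)cc1)(c1ccc(C(F)(F)F)cc1)c1cccnc1` gives 56400 nM
- compound 3 `CC(C)Oc1ccc(C(O)(c2ccc(Cl)cc2)c2cccnc2)cc1` gives 56600 nM

Compound 2 lies within the scatter of both other compounds. Compound 4 `NC(=O)c1cccc(C(O)(c2ccc(C(F)(F)F)cc2)c2cccnc2)c1` carries 3-carbamoylphenyl in place of 4-chlorophenyl on the saturated chain carbon: 3-carbamoylphenyl in place of 4-chlorophenyl on a saturated chain carbon bound to two aromatic carbons and an oxygen on a saturated carbon. For the measured compounds named here, two measured steps bear on this only loosely. Pyridin-3-yl in place of pyrimidin-5-yl gave a 1.2-fold lower number from compound 1 to compound 2 (0.07 log units; within the scatter), and isopropoxy in place of trifluoromethyl gave a 1.0-fold higher number from compound 2 to compound 3 (0.00 log units; within the scatter). Neither replaces the 4-chlorophenyl, so the evidence is indirect. Since both steps stayed small, no change beyond the scatter is expected in this assay, and the expected step is a 1.2-fold higher number from compound 2 to compound 4 (0.06 log units; within the scatter). For compound 4 the estimated value is 65000 nM, with an expected range of 30000 nM to 140000 nM.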

Compound 4, half-maximal inhibitory concentration: > 100000 nM
Compound 4 was reported as a limit; the forecaster's own chance of this, stated with the estimate: 25%; middle value at least 1.5-fold (0.18 log units) away from the limit.
By their numbers in this assay, from the lowest: compounds 2, 3 and 1 (each within the scatter of the next). At a limit, above all of these: compound 4.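

The earlier compounds shown here left the 4-chlorophenyl untouched, whereas 3-carbamoylphenyl in its place gives an at least 1.7-fold higher number from compound 2 to compound 4 (0.24 log units; that floor lies within the scatter) in this assay. Compound 4 is reported only as a limit, > 100000 nM. This change at the saturated chain carbon therefore brought no lower number, but its full size cannot be read because the reading stops at a limit: the limit of > 100000 nM in this assay, at which 1 of the 4 values shown sits.

As far as these compounds go, it remains open whether a carboxylic acid or an amine in place of the carbamoyl group would give a number that can be read. From the compounds shown here alone, it is also open whether a plain phenyl would behave like 4-chlorophenyl or like 3-carbamoylphenyl.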